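The source may report more compounds than this note shows. Statements on the series, on what has been measured and on what is new or still open speak of the compounds shown alone.

Measured in an assay on HEK293 cells for positive allosteric modulation of metabotropic glutamate receptor 5 (Homo sapiens), read by FLIPR; a lower number here means that less compound is needed, a higher number that more compound is needed for the effect:
- compound 1 `CC1CCC(C(=O)N2CC(c3nc(-c4cccc(Cl)c4)no3)C2)CC1`: 1500 nM
- compound 2 `Cc1ccc(S(=O)(=O)N2CC(c3nc(-c4cccc(C)c4)no3)C2)cc1`: > 10000 nM
- compound 3 `O=C(C1CCC(C(F)(F)F)CC1)N1CC(c2nc(-c3cccc(Cl)c3)no2)C1`: 1000 nM

The value of compound 2 is a limit of this assay, not a number. Among the two numbers, compound 1 has the higher one; its nearest neighbour is compound 3, and the difference a 1.5-fold lower number from compound 1 to compound 3 (0.18 log units; within the scatter) lies within the scatter, so no order between these two can be read. For the measured compounds named here, the only measured single-point step, trifluoromethyl in place of methyl on a saturated ring carbon, changed little.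

Compound 4 `O=C(c1ccc(F)cc1)N1CC(c2nc(-c3cccc(Cl)c3)no2)C1` differs from compound 1 as follows: 4-fluorophenyl in place of 4-methylcyclohexyl on a carbonyl carbon. Going by the values given here, no measured step touches this position or exchanges a saturated ring for an aromatic one, so the expectation rests on compound 1 alone, with a wide range. Compound 4 is expected to give about 1500 nM in this assay, between 400 nM and 6000 nM, a step of no change at the digits printed from compound 1 to compound 4 (within the scatter) that is itself within the scatter.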

Compound 4, half-maximal effective concentration: > 10000 nM
Compound 4 was reported as a limit; the forecaster's own chance of this, stated with the estimate: 15%; middle value at least 6.6-fold (0.82 log units) away from the limit.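

For the compounds shown here, exchanging the saturated ring on the carbonyl carbon for an aromatic one is the first change to matter, with 4-fluorophenyl in place of 4-methylcyclohexyl giving an at least 6.6-fold higher number from compound 1 to compound 4 (0.82 log units; beyond the scatter). The two groups match in heavy atoms and in hydrogen-bond donors and acceptors, so those counts do not separate them. For compound 4, > 10000 nM is a limit of this assay, not a number, and such limits are already common among these compounds: the limit of > 10000 nM in this assay, at which 2 of the 4 values shown sit.

Going by these compounds, how far compound 4 lies past that limit remains open. Also open, on these data alone, is whether the aromatic ring or its fluorine carries the effect, and whether plain phenyl, or cyclohexyl bearing an amine or a carboxylic acid, would return a measurable number.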